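The source may hold more compounds than are shown below. What is called first, only, known or untested is meant among the compounds shown, and "the series" means these compounds.

Measured compounds:
Compound 1 `Cc1ccc(S(=O)(=O)/N=C(/CCNC2=CC(=O)c3ccccc3C2=O)Nc2ccccc2I)cc1` gives 15500 nM in a functional assay on MCF7 cells (Homo sapiens) for cytotoxicity, read by MTT assay, with a stated time of 48 h; on this read-out lower numbers stand for stronger inhibition and higher numbers for weaker inhibition.
Compound 2 `COc1ccc(N/C(CCNC2=CC(=O)c3ccccc3C2=O)=N\S(=O)(=O)c2ccc(C)cc2)cc1OC` gives 12300 nM.
Compound 3 `COc1ccc(N/C(CCNC2=C(Br)C(=O)c3ccccc3C2=O)=N\S(=O)(=O)c2ccc(C)cc2)cc1OC` gives 6610 nM.

Compound 2 sits between the other two, separated from each by a step within the usual scatter: a 1.3-fold lower number from compound 1 to compound 2 (0.10 log units; within the scatter) and a 1.9-fold lower number from compound 2 to compound 3 (0.27 log units; within the scatter). Compound 4 `COc1ccc(N/C(CCNC2=CC(=O)C(C)=C(C)C2=O)=N\S(=O)(=O)c2ccc(C)cc2)cc1OC` differs from compound 2 by a group of 10 heavy atoms (8 carbon, 2 oxygen; one six-membered non-aromatic ring of carbon only) in place of a group of 12 heavy atoms (10 carbon, 2 oxygen; one six-membered non-aromatic ring of carbon only, one six-membered aromatic ring of carbon only), on an amine nitrogen. Neither measured step touches this part of the molecule; one altered the group on the other amine nitrogen, the other a ring carbon, and both stayed within the scatter. There is thus no measured basis for a direction, and no step beyond the scatter is expected in this assay, with wide uncertainty. Compound 4 is therefore expected to give about 13000 nM, within a range of 4000 nM to 40000 nM, an expected step of a 1.1-fold higher number from compound 2 to compound 4 (0.02 log units; within the scatter).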

Compound 4, half-maximal inhibitory concentration: 8710 nM
Beside the measured number, compound 4's estimate is 1.5-fold (0.17 log units) above it, and the stated range covers the measured number.
By their numbers in this assay, from the lowest: compounds 3, 4, 2 and 1 (each within the scatter of the next, the first and the last beyond it).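

Swapping the group of 12 heavy atoms on this amine nitrogen for the group of 10 heavy atoms gives a 1.4-fold lower number from compound 2 to compound 4 (0.15 log units; within the scatter) in this assay. Going by these compounds alone, this is the first look at that position, and it shows that the six-membered aromatic ring of the group can be absent without a step beyond the scatter. Nothing measured here accounts for the result.

Still open, as far as these compounds go, is whether a carboxylic acid or a longer chain at this position would give a step beyond the scatter. Also open, from the compounds shown here alone, is how bromo on the double-bonded ring carbon would act in compound 4.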